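Nitro for Trifluoromethyl in a Cytotoxicity Series

The compounds below may be only part of what the source reports. "The series", "measured", "known", "first", "only" and "open" are said of these compounds alone.

Measured compounds:
Compound 1, `O=C(NCCCCC(c1ccc(F)cc1)c1ccc(F)cc1)Nc1ccc(Cl)c(C(F)(F)F)c1`, gives 3150 nM in a functional assay on MDA-MB-231 cells (Homo sapiens) for cytotoxicity, read by MTT assay, with a stated time of 48 h; a higher number here means a weaker inhibitor, a lower number a stronger inhibitor.
Compound 2, `O=C(NCCCCC(c1ccc(F)cc1)c1ccc(F)cc1)Nc1ccc(Cl)c([N+](=O)[O-])c1`, gives 4060 nM in this assay.
Compound 3, `COc1ccc(C(CCCCNC(=O)Nc2ccc(Cl)c(C(F)(F)F)c2)c2ccc(OC)cc2)cc1`, gives 3300 nM in this assay.

The three measured compounds share a urea linking an aryl amine to a chain that ends in a diaryl methine, and all three give numbers of the same order in this assay. Compound 1 and compound 2 differ in a single place, (nitro in place of trifluoromethyl on an aromatic carbon), and the step that goes with it is a 1.3-fold higher number from compound 1 to compound 2 (0.11 log units; within the scatter). Compound 3 carries a different core; the difference between its core and that of compound 1 is not broken down here, and the two values of compound 1 and compound 3 simply show no separation beyond the scatter.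

Compound 4, `COc1ccc(C(CCCCNC(=O)Nc2ccc(Cl)c([N+](=O)[O-])c2)c2ccc(OC)cc2)cc1`, has not yet been measured. It stands to compound 3 as compound 2 stands to compound 1: nitro in place of trifluoromethyl on an aromatic carbon. The place lines of the two changes read the same word for word, so this is the same change made on the second core.

Going by the values given here, since the same change gave only a 1.3-fold higher number from compound 1 to compound 2 (0.11 log units; within the scatter) on the first core, the step from compound 3 to compound 4 is expected to be of similar size, a 1.3-fold higher number from compound 3 to compound 4 (0.10 log units; within the scatter), because the only precedent is the step from compound 1 to compound 2 and because compound 3 gives 3300 nM. On that basis compound 4 is estimated at 4200 nM, with a likely range from 2400 nM to 7500 nM.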

Compound 4, half-maximal inhibitory concentration: 3990 nM
For compound 4 the middle estimate is 1.1-fold (0.02 log units) above the measured one; measured number inside the range.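

In this assay, the step on the second core is a 1.2-fold higher number from compound 3 to compound 4 (0.08 log units; within the scatter), so nitro in place of trifluoromethyl produces no separation on this core. Set beside the earlier step, the change reads alike on the two cores, and the gap between the steps gives no sign that the core alters its effect: the same change on two cores in this assay, a 1.3-fold higher number (0.11 log units; within the scatter) from compound 1 to compound 2 and a 1.2-fold higher number (0.08 log units; within the scatter) from compound 3 to compound 4, 1.1-fold (0.03 log units) apart, within the scatter of two such steps. This shows that, on these two cores, the exchange carries over as a step too small to stand out from the scatter, but it does not show a real shared effect of the change, and it says nothing about how the same exchange would behave on any other core.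

Among the compounds shown, only trifluoromethyl and nitro occupy this place on the ring, so it remains open how a nitrile, an amine or a carboxylic acid there would read in this assay. The urea and the chain also stay the same throughout, which leaves open what an amide in place of the urea, or a shorter or longer chain, would do to these numbers.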